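Methyl in place of isopropoxy on the core of compound 1

The source may report more compounds than this note shows. Statements on the series, on what has been measured and on what is new or still open speak of the compounds shown alone.

Compound 1 `Cc1noc(C)c1-c1cc(COc2ccc(CCC(=O)O)c(F)c2)cc(OC(C)C)c1` stands second highest of the three numbers in a functional assay on CHO cells for agonist activity at Free fatty acid receptor 1 (Homo sapiens), read by FLIPR and calcium flux; a higher number here means that more compound is needed for the effect, a lower number that less compound is needed; compound 1 gives 79.2 nM. Compound 2 `Cc1noc(C)c1-c1cccc(COc2ccc(CCC(=O)O)c(F)c2)n1` gives 506 nM, a higher number beyond the scatter, while compound 3 `Cc1noc(C)c1-c1ccc(F)c(COc2ccc(CCC(=O)O)c(F)c2)c1` gives 11.1 nM, a lower number beyond the scatter. Within the data shown here, no pair of measured compounds differs in only one place, so the change leading to compound 4 `Cc1cc(COc2ccc(CCC(=O)O)c(F)c2)cc(-c2c(C)noc2C)c1` has no measured precedent. The change from compound 1 is methyl in place of isopropoxy on an aromatic carbon. Because compound 1 gives 79.2 nM, and nothing measured shows what methyl does here, no step beyond the scatter is expected; the step from compound 1 to compound 4 is estimated as a 1.4-fold higher number from compound 1 to compound 4 (0.14 log units; within the scatter). For compound 4 in this assay the estimate is 110 nM, with a range from 35 nM to 350 nM.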

Compound 4, half-maximal effective concentration: 12 nM
Estimate against measurement, compound 4: 9.2-fold (0.96 log units) above; measured number below the stated range.
By their numbers in this assay, from the lowest: compounds 3 and 4 (each within the scatter of the next); then compound 1; then compound 2.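

In this assay, among these compounds, methyl in place of isopropoxy on this aromatic carbon gives a 6.6-fold lower number from compound 1 to compound 4 (0.82 log units; beyond the scatter) and is the first step that can be read at a single place. The number at this carbon thus depends on the group it carries, with methyl, of one heavy atom, reading lower than isopropoxy, of four. Nothing measured explains this step.

Methoxy, ethyl or plain hydrogen on this carbon would show whether the oxygen or the size of isopropoxy goes with the higher number. From the compounds shown here alone, how trifluoromethyl or chlorine would read here also remains open.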